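The source may hold more compounds than are shown below. What is called first, only, known or untested is meant among the compounds shown, and "the series" means these compounds.

Among the measured compounds shown here, in a functional assay on RAW264.7 cells (Mus musculus) for inhibition, read by Griess assay, with stated times of 1 h and 24 h (on this read-out higher numbers stand for weaker inhibition and lower numbers for stronger inhibition), compound 2 (`COc1cc(OC)c2c(c1)C(C(O)c1ccc(OCc3ccc(Br)cc3)cc1)OC2=O`) gives 6530 nM as the only actual number so far. Compound 1 (`COCCOc1ccc(C(O)C2OC(=O)c3c(OC)cc(OC)cc32)cc1`) gives > 10000 nM in this assay and that value is a limit of the assay, not a number. For the measured compounds named here, the one measured step is an at least 1.5-fold lower number from compound 1 to compound 2 (0.18 log units; that floor lies within the scatter) for this pair; its floor lies within the scatter, so the two compounds cannot be ranked from it. Compound 3 (`COc1cc(OC)c2c(c1)C(C(O)c1ccc(OCC3CCCCC3)cc1)OC2=O`) carries cyclohexyl in place of 4-bromophenyl on a saturated chain carbon bound to an oxygen on an aromatic ring, and the full count reads cyclohexyl in place of 4-bromophenyl on a saturated chain carbon bound to an oxygen on an aromatic ring for this change. Going by the values given here, the step to compound 2 at this same place is the only evidence that bears on the change, and it does not test a non-aromatic ring. No shift beyond the scatter is therefore expected in this assay and no direction is favoured, so the expected size is a 1.1-fold higher number from compound 2 to compound 3 (0.03 log units; within the scatter) on this estimate. A reading at the assay limit remains possible. Compound 3 is estimated at 7000 nM with an expected range from 3000 nM to 15000 nM in this read-out.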

Compound 3, half-maximal inhibitory concentration: > 10000 nM
Compound 3: no number, only a limit; the forecaster's own chance of this, stated with the estimate: 35%; middle value at least 1.4-fold (0.15 log units) away from the limit.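

In this assay compound 3 gives > 10000 nM, which is a limit of the assay and not a number. Among the compounds shown here, this is the first non-aromatic ring at this place, and the step reads an at least 1.5-fold higher number from compound 2 to compound 3 (0.18 log units; that floor lies within the scatter), so cyclohexyl in place of 4-bromophenyl gives no ranking of the two compounds, and the true size and direction of the change stay unknown. The step from compound 1 to compound 3 cannot be read, and the series still rests on one actual number, with the other readings sitting at the same limit: the limit of > 10000 nM in this assay, at which 2 of the 3 values shown sit.

For the compounds shown here, open is whether the aromatic ring or the bromine of compound 2 matters at all, since no step here separates the two; a plain phenyl in place of 4-bromophenyl would do that. Also open, as far as these compounds go, is whether any other group on this saturated chain carbon gives a reading clear of the limit and the scatter, for example a terminal amine, a carboxylic acid, or a longer chain carrying the same cyclohexyl ring.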